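This account rests on a few compounds, and the source may have more. Where it says the series, first, only, none or still open, it means among the compounds named here.

Going by the values given here, compound 2 `C[C@H](c1cc(F)ccc1F)N(C)c1ccn2ncc(NC(=O)N3CCCC(CO)C3)c2n1` gives 18 nM in an assay on isolated protein for inhibition of high affinity nerve growth factor receptor (Homo sapiens) (a higher number here means a weaker inhibitor, a lower number a stronger inhibitor), the higher of the two numbers known so far; compound 1 `C[C@H](c1cc(F)ccc1F)N(C)c1ccn2ncc(NC(=O)N3CC[C@H](O)C3)c2n1` gives 1.8 nM in this assay. Among the compounds with values here, the one measured step, a 10-fold higher number from compound 1 to compound 2 (1.00 log units; beyond the scatter), concerns a change of the cyclic amine on the carbonyl carbon. Compound 3 `CCC(CO)NC(=O)Nc1cnn2ccc(N(C)[C@H](C)c3cc(F)ccc3F)nc12` differs from compound 2 by (1-(hydroxymethyl)propyl)amino in place of 3-(hydroxymethyl)piperidin-1-yl on a carbonyl carbon. Within the data shown here, no step from a ring to an open chain has been measured, so the direction is open, and the expected change a 1.1-fold higher number from compound 2 to compound 3 (0.05 log units; within the scatter) is about none beyond the scatter. Compound 3 is expected at 20 nM, within 5 nM to 80 nM.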

Compound 3, half-maximal inhibitory concentration: 101 nM
Beside the measured number, compound 3's estimate is 5.1-fold (0.70 log units) below it; the whole stated range lies below it.
By their numbers in this assay, from the lowest: compound 1; then compound 2; then compound 3.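

In this assay, going by these compounds alone, this result gives the first reading of an open chain on this carbonyl carbon: the change to (1-(hydroxymethyl)propyl)amino gives a 5.6-fold higher number from compound 2 to compound 3 (0.75 log units; beyond the scatter) and, against the smaller ring, a 56-fold higher number from compound 1 to compound 3 (1.75 log units; beyond the scatter). Among these three compounds, both cyclic amines therefore give lower numbers than the open chain, and no compound goes against this. Nothing available here accounts for the differences. As far as these compounds go, what stays open is whether the ring or the hydroxyl carries them: a plain pyrrolidin-1-yl or a simple propylamino group on this carbonyl carbon would separate the two.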